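Swapping the Aryl Group on the Shared Core

The source may report more compounds than this note shows. Statements on the series, on what has been measured and on what is new or still open speak of the compounds shown alone.

Of the compounds shown here, three have been measured in an ADME assay on microsomes from liver (Homo sapiens) for metabolic stability, tested at 2.5 uM; on this read-out higher numbers stand for fast clearance and lower numbers for slow clearance. Compound 2, `COc1cccc(-c2c(S(=O)(=O)c3ccc(OC)c(Cl)c3)cnc3cc(F)ccc23)c1`, gives 1.71 mL/min, the highest of the three numbers. Compound 3, `O=S(=O)(c1cc(Cl)cc(Cl)c1)c1cnc2c(F)cccc2c1-c1cccc(Cl)c1`, gives 1.2 mL/min, which lies within the scatter of compound 2, so the two cannot be told apart on this read-out. Compound 1, `O=S(=O)(c1ccc(F)c(Cl)c1)c1cnc2c(F)cccc2c1-c1cccc(Cl)c1`, gives 0.18 mL/min, well below compound 2 and beyond the scatter. Going by the values given here, the only single-point step among the measured compounds, a 6.7-fold higher number from compound 1 to compound 3 (0.82 log units; beyond the scatter), concerns the group on the sulfonyl sulfur and nothing else.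

The unmeasured compound 4, `COc1ccc(S(=O)(=O)c2cnc3cc(F)ccc3c2-c2ccc(F)cc2)cc1Cl`, differs from compound 2 at a different place: 4-fluorophenyl in place of 3-methoxyphenyl on an aromatic carbon. No measured step touches the aryl group on that aromatic carbon, so nothing among these three compounds shows how this exchange moves the read-out. The 3-methoxyphenyl of compound 2 becomes a 4-fluorophenyl in compound 4, while the group on the sulfonyl sulfur stays as it is in compound 2. Among the compounds with values here, with no step bearing on the change, the expected outcome for compound 4 is a step of a 1.1-fold lower number from compound 2 to compound 4 (0.06 log units; within the scatter), within the scatter. Compound 4 is therefore estimated at 1.5 mL/min, with a range from 0.7 mL/min to 3.2 mL/min.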

Compound 4, intrinsic clearance in a liver preparation (reported as CLH), per the amount of preparation that the assay uses: 1.29 mL/min
The estimate for compound 4 lay 1.2-fold (0.07 log units) above the measured number; low and high end bracket the measured number.
By their numbers in this assay, from the lowest: compound 1; then compounds 3, 4 and 2 (each within the scatter of the next).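

Going by these compounds alone, this is the first measured exchange on the aromatic carbon opposite the ring nitrogen, and in this assay it gives a 1.3-fold lower number from compound 2 to compound 4 (0.12 log units; within the scatter), so 4-fluorophenyl in place of 3-methoxyphenyl leaves the read-out within the scatter while the group on the sulfonyl sulfur stays the same. The leaving group has 1 hydrogen-bond acceptor and the entering group has 0 hydrogen-bond acceptors, yet on this background that difference comes with no step beyond the scatter. Nothing available explains why the read-out holds across this exchange.

A single exchange on a single background leaves open whether the read-out would also hold with other groups on this aromatic carbon, such as a morpholine, a carboxylic acid or a longer alkyl chain. Also open, as far as these compounds go, is whether the number of compound 1, 0.18 mL/min, would carry over to the core of compound 4 with 3-chloro-4-fluorophenyl on the sulfonyl sulfur, and whether 4-fluorophenyl would behave the same way in that setting.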